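Compound 1 to compound 4: an aryl swap

The compounds below may be only part of what the source reports. "The series", "measured", "known", "first", "only" and "open" are said of these compounds alone.

Values in a functional assay on A-375 cells (Homo sapiens) for antiproliferative activity, read by MTT assay, with a stated time of 72 h; on this read-out higher numbers stand for weaker inhibition and lower numbers for stronger inhibition:
- compound 1 `COc1cccc(N2C(=O)COc3ccc(-c4cnc5ccccc5c4)cc32)c1`: 23600 nM
- compound 2 `COc1ncc(-c2ccc3c(c2)N(c2ccccc2)C(=O)CO3)cc1NS(=O)(=O)c1ccc(F)cc1`: 15200 nM
- compound 3 `O=C1COc2ccc(-c3cnc(Cl)c(NS(=O)(=O)c4ccc(F)cc4)c3)cc2N1`: > 40000 nM (a limit of the assay, not a number)

Compound 1 stands level with compound 2 in this assay, as their two numbers lie within the usual scatter of each other. Compound 3 reports only a limit, > 40000 nM. That limit is the upper edge of what can be read here: the limit of > 40000 nM in this assay, at which 1 of the 3 values shown sits.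

The next compound is compound 4 `O=C1COc2ccc(-c3cnc4ccccc4c3)cc2N1c1ccc(F)cc1`, which has 4-fluorophenyl in place of 3-methoxyphenyl on an amide-type nitrogen in a ring. Going by the values given here, the series offers no measured step between compounds that differ in one place, so nothing isolates this change. The expectation therefore rests on the narrow spread of compound 1 at 23600 nM and compound 2 at 15200 nM. No step beyond the scatter is expected in this assay, and no direction is favoured with any confidence. The expected change is a 1.2-fold lower number from compound 1 to compound 4 (0.07 log units; within the scatter). Compound 4 is expected at 20000 nM, with an estimated range from 8000 nM to 40000 nM.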

Compound 4, half-maximal inhibitory concentration: > 40000 nM
Compound 4: no number, only a limit (the forecaster's own chance of this, stated with the estimate: 25%); middle value at least 2.0-fold (0.30 log units) from the limit.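

Compound 4 reports > 40000 nM in this assay, which is a limit of the assay and not a number. Going by these compounds alone, this gives the first one-place comparison on the amide-type nitrogen in a ring, an at least 1.6-fold higher number from compound 1 to compound 4 (0.22 log units; that floor lies within the scatter), so the swap of 3-methoxyphenyl for 4-fluorophenyl gives no gain in inhibition that can be read here, while the true size of the step stays unknown. The upper edge of the read-out now holds a second compound: the limit of > 40000 nM in this assay, at which 2 of the 4 values shown sit.

Still open, from the compounds shown here alone, is whether an amine or a carboxylic acid on the phenyl ring at this nitrogen would give a measurable number. Also open, going by these compounds, is whether the same swap would read differently on the substituted pyridine side of compound 2, whose values allow no one-place comparison here.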